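The compounds below may be only part of what the source reports. "The series", "measured", "known", "first", "only" and "open" are said of these compounds alone.

In a functional assay on MGC-803 cells (Homo sapiens) for antiproliferative activity, read by MTT assay, with a stated time of 72 h (a lower number here means a stronger inhibitor, a higher number a weaker inhibitor), compound 1 (`O=C(NO)c1ccc(NCc2nc(-c3cccc(Cl)c3)nn2-c2ccccc2)cc1`) gives 5760 nM and compound 2 (`O=C(NO)c1ccc(NCc2nc(-c3ccccc3)nn2-c2ccc(Br)cc2)cc1`) gives 9300 nM. Compound 2 therefore stands within the usual scatter of compound 1, and the two numbers cannot be told apart.

Compound 3 (`O=C(NO)c1ccc(NCc2nc(-c3ccccc3)nn2-c2ccccc2)cc1`) has not yet been measured. It is compound 2 with hydrogen in place of bromo on an aromatic carbon, para to a large group, so that 4-bromophenyl becomes phenyl: hydrogen in place of bromo on an aromatic carbon. For the measured compounds named here, no two measured compounds differ in one place only, so the data offer no direct precedent for this change.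

In this assay, no step beyond the scatter is expected in either direction. This expectation rests only on the closeness of compound 2 at 9300 nM and compound 1 at 5760 nM, and it is correspondingly loose. The estimated step of a 1.3-fold lower number from compound 2 to compound 3 (0.12 log units; within the scatter) stays within the scatter. For compound 3 the expected value is 7000 nM, with an estimated range from 2500 nM to 18000 nM.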

Compound 3, half-maximal inhibitory concentration: 17700 nM
Beside the measured number, compound 3's estimate is 2.5-fold (0.40 log units) below it; the range from low to high includes it.
By their numbers in this assay, from the lowest: compounds 1, 2 and 3 (each within the scatter of the next, the first and the last beyond it).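

With hydrogen in place of bromo on the aromatic carbon para to a large group, the series gains its first direct reading of this position: in this assay the change from 4-bromophenyl to phenyl is a 1.9-fold higher number from compound 2 to compound 3 (0.28 log units; within the scatter), so the bromo group cannot be told from hydrogen here. The same unsubstituted compound also gives the series its first step beyond the scatter, as the loss of the chloro group is a 3.1-fold higher number from compound 1 to compound 3 (0.49 log units; beyond the scatter), a modest step, and so the chloro group of compound 1 is the only one of the two halogens whose loss can be read. No measurement at hand accounts for this difference between the two single changes.

Going by these compounds, it remains open whether a methoxy group, an amine or a carboxylic acid on the para carbon of the phenyl ring would give a step beyond the scatter, or would read like bromo and hydrogen. On these data alone, it is also open how bromo would read on the carbon that carries chloro in compound 1, and how chloro would read on the carbon that carries bromo in compound 2.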